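The compounds below may be only part of what the source reports. "The series", "measured", "known", "first", "only" and "open" are said of these compounds alone.

Compound 2 `O=C(Nc1cccc(CNc2nccnc2Cl)c1)NC1CCCC1` carries a cyclopentyl group on one amide-type nitrogen of the shared core. In a functional assay on T-24 cells (Homo sapiens) for antiproliferative activity, read by MTT assay, with a stated time of 48 h (a higher number here means a weaker inhibitor, a lower number a stronger inhibitor), compound 2 reaches only a limit of the assay, > 40000 nM. Compound 1 `O=C(Nc1cccc(CNc2nccnc2Cl)c1)Nc1ccc(F)c(Cl)c1`, with a 3-chloro-4-fluorophenyl group there instead, gives 4990 nM, and the step of an at least 8.0-fold higher number from compound 1 to compound 2 (0.90 log units; beyond the scatter) can only be given as a bound because compound 2 sits at the limit of > 40000 nM in this assay, at which 1 of the 3 values shown sits. Compound 3 `CS(=O)(=O)c1ccc(NC(=O)Nc2cccc(CNc3nccnc3Cl)c2)cc1`, with another aryl group on that nitrogen, gives 29300 nM. Compound 4 `O=C(Nc1cccc(CNc2nccnc2Cl)c1)Nc1ccc(Cl)cc1Br` differs from compound 2 by 2-bromo-4-chlorophenyl in place of cyclopentyl on an amide-type nitrogen. Since compound 1 with its halogenated phenyl gave 4990 nM, a return toward that level is expected, and the step of an at least 5.7-fold lower number from compound 2 to compound 4 (0.75 log units; beyond the scatter) is estimated to go down. Compound 4 is therefore expected at about 7000 nM, within 2500 nM to 25000 nM.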

Compound 4, half-maximal inhibitory concentration: 6650 nM
Compound 4: middle estimate off by 1.1-fold (0.02 log units), on the high side; low and high end bracket the measured number.
By their numbers in this assay, from the lowest: compounds 1 and 4 (each within the scatter of the next); then compound 3. At a limit, above all of these: compound 2.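

Putting 2-bromo-4-chlorophenyl in place of cyclopentyl on this amide-type nitrogen gives an at least 6.0-fold lower number from compound 2 to compound 4 (0.77 log units; beyond the scatter), so a second halogenated phenyl also stands clear of the cyclopentyl compound. That step is only a bound, since one end of it is a limit of the assay: the limit of > 40000 nM in this assay, at which 1 of the 4 values shown sits. Exchanging 3-chloro-4-fluorophenyl for 2-bromo-4-chlorophenyl gives a 1.3-fold higher number from compound 1 to compound 4 (0.12 log units; within the scatter), so these two halogenated phenyl groups cannot be told apart here.

Going by these compounds, whether an unsubstituted phenyl or a methoxyphenyl would match them remains open. So does whether the halogens themselves matter, or the phenyl ring alone.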